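The source may hold more compounds than are shown below. What is called first, only, known or untested is meant among the compounds shown, and "the series" means these compounds.

Measured compounds:
- compound 1, `Nc1cc(N)c2nc(-c3ccccc3)c(Sc3ccc(F)cc3)nc2c1`: 31600 nM
- compound 2, `COc1ccc(CNc2nc3cc(N)cc(N)c3nc2-c2ccccc2)cc1`: 26300 nM

Of the compounds shown here, two with a shared core have been tested in a functional assay on U-251 cells (Homo sapiens) for inhibition, read by sulforhodamine B assay, with a stated time of 48 h; on this read-out higher numbers stand for weaker inhibition of growth and lower numbers for stronger inhibition of growth. Compound 1 gives 31600 nM, the highest of the two numbers; compound 2 gives 26300 nM, and the gap between them lies within the scatter of repeated measurements, so the two show no difference that can be read as a real one. Compound 3, `COc1ccc(Sc2nc3cc(N)cc(N)c3nc2-c2ccccc2)cc1`, has not yet been measured. It differs from compound 1 in one place: methoxy in place of fluoro on an aromatic carbon. The fluoro group leaves and a methoxy group enters on the same aromatic carbon, which brings one more hydrogen-bond acceptor. Within the data shown here, no measured pair shows what such a swap does here, so there is nothing in the data to point toward a stronger or weaker effect. The step from compound 1 to compound 3 in this assay is expected to be small, a 1.1-fold lower number from compound 1 to compound 3 (0.05 log units; within the scatter), not clearly beyond the scatter. Compound 3 is therefore estimated to give 28000 nM, within a range from 11000 nM to 70000 nM.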

Compound 3, concentration for total growth inhibition: < 100000 nM
Compound 3 was reported as a limit; the forecaster's own chance of this, stated with the estimate: 10%; the middle value lies beyond the limit too.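

Compound 3 is reported only as a limit, not a number, so no step from compound 1 to compound 3 can be read: the limit of < 100000 nM in this assay, at which 1 of the 3 values shown sits.

The compounds shown leave open what methoxy in place of fluoro on this aromatic carbon does to growth inhibition.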